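This account rests on a few compounds, and the source may have more. Where it says the series, first, only, none or still open, it means among the compounds named here.

Measured compounds in a functional assay on PC-3 cells (Homo sapiens) for inhibition, read by sulforhodamine B assay, with a stated time of 48 h; a lower number here means a stronger inhibitor of growth, a higher number a weaker inhibitor of growth:
- compound 1 `COC1=C(OC)[C@H](O)[C@H](C/C=C(\C)CC/C=C(\C)CCC=C(C)C)[C@@H](C)C1=O` gives 13500 nM
- compound 2 `COC1=C(OC)C(=O)C(C/C=C(\C)CC/C=C(\C)C[C@H](O)C=C(C)C)=C(C)C1=O` returns only a limit of the assay, > 30000 nM

For the measured compounds named here, compound 1 holds the only numerical value in this assay; the other entry is a limit, not a number. Going by the values given here, compound 1 is a weak growth inhibitor on this reading, and the remaining entry sits at the limit of > 30000 nM in this assay, at which 1 of the 2 values shown sits, so the measured pair gives no usable step and no direction to lean on.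

Compound 3 `COC1=C(OC)[C@H](O)[C@H](C/C=C(\C)CC/C=C(\C)CCCC(C)CO)[C@@H](C)C1=O` is not yet measured. It differs from compound 1 in one place: 2-(hydroxymethyl)propyl in place of 2-methylprop-1-en-1-yl on a saturated chain carbon, two bonds along the chain from a double-bonded chain carbon. The shared core and the rest of the chain are untouched; the change is at the far end of the chain.

Among the compounds with values here, with no measured step between compounds that differ in one place, the size of the step in this assay cannot be read from the data. The expectation is that the step from compound 1 to compound 3 stays within the usual scatter, or drifts slightly toward weaker inhibition, since a hydroxyl group is the only new feature. Compound 3 is expected to give about 17000 nM, with the estimate spanning 7000 nM to 40000 nM, meaning a step of a 1.3-fold higher number from compound 1 to compound 3 (0.10 log units; within the scatter).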

Compound 3, concentration for 50% growth inhibition: > 30000 nM
Compound 3: no number, only a limit; the forecaster's own chance of this, stated with the estimate: 30%; at least 1.7-fold (0.24 log units) between middle value and limit.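

In this assay, the chain end gives its first readable step: 2-(hydroxymethyl)propyl in place of 2-methylprop-1-en-1-yl, on a saturated chain carbon, two bonds along the chain from a double-bonded chain carbon, gives an at least 2.2-fold higher number from compound 1 to compound 3 (0.34 log units; beyond the scatter). Compound 3 shows > 30000 nM, which is a limit of the assay and not a number, so the step has a lower bound but no measured size. The far end of the chain is therefore not a silent place, as this change takes the read-out from a number to a limit, and limits now make up most of the series: the limit of > 30000 nM in this assay, at which 2 of the 3 values shown sit.

The step changes the chain end's double bond and adds a hydroxyl at once, and the compounds shown do not separate these two changes; steps involving compound 2 cannot be read. As far as these compounds go, how a plain saturated 2-methylpropyl end, a carboxylic acid or an amine at this place would read in this assay remains open.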